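This account rests on a few compounds, and the source may have more. Where it says the series, first, only, none or still open, it means among the compounds named here.

Compound 1, `C=Cc1c(C)nn(CCCN2CCN(c3ccc(F)cc3)CC2)c(=O)c1N`, gives 28% in a functional assay on the whole organism (Abdomen, strain Swiss) for inhibition, with Mus musculus as the target, with stated times of 30 min, 10 min and 5 min, at a dose of 30 mg/kg by the oral route; a higher number here means a stronger effect of the compound at the dose given, a lower number a weaker effect.
Compound 2, `C=Cc1c(C)nn(CCCCN2CCN(c3ccc(C)cc3)CC2)c(=O)c1N`, gives 42% in this assay.

Of these two numbers, compound 2 stands highest; compound 1 lies lower by a margin beyond the usual scatter of this assay. Compound 3, `C=Cc1c(C)nn(CCCCN2CCN(c3ccccc3OCC)CC2)c(=O)c1N`, has not yet been measured. It differs from compound 2 in one place: 2-ethoxyphenyl in place of 4-methylphenyl on an amine nitrogen in a ring. For the measured compounds named here, no measured pair shows a change of this kind, so there is no step to lean on. The expected step is a number 7 percentage points lower from compound 2 to compound 3 (within the scatter), a small move downward that stays within the scatter. Compound 3 is estimated to give 35%, between 15% and 55%.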

Compound 3, a percentage reported as inhibition, in the whole organism at one dose (the size of the read-out at that dose, not a potency): "not active" (no number reported)
Nothing numeric was reported for compound 3, so the estimate cannot be set against anything.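

Compound 3 is reported only as not active, with no number, so no step from compound 2 to compound 3 can be read, and no measurement shown explains this result. Going by these compounds, how large the effect of exchanging 4-methylphenyl for 2-ethoxyphenyl is remains open.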